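The compounds below may be only part of what the source reports. "The series", "measured", "known", "first", "only" and "open" are said of these compounds alone.

Series notes. The shared core is held constant and only the aryl group on the amide-type nitrogen varies. Compound 1 `COc1cccc(NC(=O)COc2ccc3cc(/C=C4/SC(=O)NC4=O)ccc3c2)c1` in an assay on isolated protein for inhibition of histone deacetylase 4 (Homo sapiens), with a stated time of 1 h (on this read-out higher numbers stand for weaker inhibition and lower numbers for stronger inhibition), gives 1600 nM. Compound 2 `O=C(COc1ccc2cc(/C=C3/SC(=O)NC3=O)ccc2c1)Nc1ccccc1` gives 2100 nM in this assay, and compound 3 `O=C(COc1ccc2cc(/C=C3/SC(=O)NC3=O)ccc2c1)Nc1ccc(F)cc1` gives 1600 nM in this assay. Compound 1 stands level with compound 3 at the digits shown, the two together the lowest of the three numbers; its furthest neighbour is compound 2, with a 1.3-fold higher number from compound 1 to compound 2 (0.12 log units; within the scatter). The step of no change at the digits printed from compound 1 to compound 3 (within the scatter) and the step of a 1.3-fold lower number from compound 2 to compound 3 (0.12 log units; within the scatter) likewise stay within the scatter. Compound 4 `O=C(COc1ccc2cc(/C=C3/SC(=O)NC3=O)ccc2c1)Nc1c(F)cc(F)cc1Br` differs from compound 1 by 2-bromo-4,6-difluorophenyl in place of 3-methoxyphenyl on an amide-type nitrogen. The three measured steps all alter this same aryl group, and none of them moved the number beyond the scatter; the change to compound 4 is larger than any of them, but nothing measured points to a direction. A step of a 1.1-fold higher number from compound 1 to compound 4 (0.05 log units; within the scatter) is therefore expected, that is, none beyond the scatter. For compound 4 in this assay the estimate is 1800 nM, with a range of 700 nM to 4500 nM.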

Compound 4, half-maximal inhibitory concentration: 1100 nM
Compound 4: the middle estimate sits 1.6-fold (0.21 log units) above what was measured; measured number inside the range.
By their numbers in this assay, from the lowest: compounds 4, 1, 3 and 2 (each within the scatter of the next).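

In this assay, the aryl group on the amide-type nitrogen now spans 3-methoxyphenyl, phenyl, 4-fluorophenyl and 2-bromo-4,6-difluorophenyl, and the new group still gives only a 1.5-fold lower number from compound 1 to compound 4 (0.16 log units; within the scatter), a 1.5-fold lower number from compound 3 to compound 4 (0.16 log units; within the scatter) and a 1.9-fold lower number from compound 2 to compound 4 (0.28 log units; within the scatter). The earlier compounds shown here showed this only for small edits to the ring; here a ring bearing bromine and two fluorines, with no hydrogen-bond acceptor in the group, also stays within the scatter of all three. No supporting data bear on how this group acts at the position.

Still open, as far as these compounds go, is whether any group other than a substituted phenyl on this nitrogen, such as a benzyl group, a pyridyl ring or a phenyl carrying a carboxylic acid or an amine, would move the number beyond the scatter. The same question applies to a longer chain between the ether oxygen and the amide carbonyl.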